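One More Carbon on the Chain of Compound 2

A few compounds are considered here, and "the series" means these few. Any claim that something is new, unique, unknown or untested is made for them only; others in the source may bear on it.

Compound 2 `CCCc1cn([C@H]2C[C@@H]3OP(=O)(O)OC[C@H]3O2)c(=O)[nH]c1=O` carries a propyl chain on its core. In a functional assay on Raji cells (Homo sapiens) (on this read-out higher numbers stand for weaker inhibition and lower numbers for stronger inhibition), compound 2 gives only a limit, > 500 ug/mL, and not a number. Compound 4 `CCCCc1cn([C@H]2C[C@@H]3OP(=O)(O)OC[C@H]3O2)c(=O)[nH]c1=O` differs from it by methyl in place of hydrogen on a saturated chain carbon, three bonds along the chain from an aromatic carbon.

The closest measured guide is a pair built on a different core. Compound 1 `CCCCCCc1cn([C@H]2C[C@H](O)[C@@H](CO)O2)c(=O)[nH]c1=O` carries a hexyl chain, and in this assay compound 1 gives 173 ug/mL. Compound 3 `CCCc1cn([C@H]2C[C@H](O)[C@@H](CO)O2)c(=O)[nH]c1=O` carries a propyl chain, and in this assay compound 3 gives only a limit, > 500 ug/mL. Shortening that chain gave an at least 2.8-fold higher number from compound 1 to compound 3 (0.46 log units; beyond the scatter), so the longer chain went with stronger inhibition; the true size of that step cannot be read exactly because of the limit of > 500 ug/mL in this assay, at which 2 of the 3 values shown sit.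

The change from propyl to butyl is smaller than the change from hexyl to propyl, so for compound 4 the expected step is an at least 1.2-fold lower number from compound 2 to compound 4 (0.09 log units; that floor lies within the scatter), a modest move toward stronger inhibition that may still leave the value at the limit. The estimate for compound 4 in this assay is 400 ug/mL, within 150 ug/mL to 1000 ug/mL.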

Compound 4, concentration for 50% inhibition: 165 ug/mL
For compound 4 the middle estimate is 2.4-fold (0.38 log units) above the measured one; the measured number falls inside the stated range.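

On the core of compound 2, the change from propyl to butyl in this assay gives an at least 3.0-fold lower number from compound 2 to compound 4 (0.48 log units; beyond the scatter), so one added methyl on this chain is enough to lower the number beyond the scatter. The earlier pair tied a longer chain to stronger inhibition only on a different core and only across the larger change from hexyl to propyl, whereas this result shows the same direction on a second core and for a much smaller change. Compound 2 gives only a limit, so the true size of this step cannot be read, because of this: the limit of > 500 ug/mL in this assay, at which 2 of the 4 values shown sit.

How far the trend runs on this core remains open, since the compounds shown stop at butyl and do not include a pentyl or hexyl chain there. Also open, on these data alone, is how a chain ending in an amine or a carboxylic acid would behave at this place.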